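Benzyl in place of 4-methylphenyl at the limit of the assay

This account rests on a few compounds, and the source may have more. Where it says the series, first, only, none or still open, it means among the compounds named here.

Compound 1 (`Cc1ccccc1Nc1nc(NC2CCCCC2)ncc1Cl`) gives > 100000 nM as a limit
Compound 2 (`Cc1ccccc1Nc1nc(Nc2ccccc2)ncc1Cl`) gives > 100000 nM as a limit
Compound 3 (`Cc1ccc(Nc2ncc(Cl)c(Nc3ccccc3C)n2)cc1`) gives > 100000 nM as a limit

These results come from a functional assay on MDA-MB-231 cells (Homo sapiens) for inhibition, read by CCK-8 assay, with a stated time of 48 h (on this read-out higher numbers stand for weaker inhibition of growth and lower numbers for stronger inhibition of growth), and all of them are limits, not numbers. As far as these compounds go, compound 3 stands at > 100000 nM as a limit, so its true place is unknown. Compound 4 (`Cc1ccccc1Nc1nc(NCc2ccccc2)ncc1Cl`) has the same atoms as compound 3, joined differently, with benzyl in place of 4-methylphenyl on a nitrogen on an aromatic ring. Changes at that nitrogen gave a step that the two limits leave unreadable from compound 1 to compound 2 and a step that the two limits leave unreadable from compound 1 to compound 3 in the same read-out. Methyl in place of hydrogen on an aromatic carbon gave a step that the two limits leave unreadable from compound 2 to compound 3 as well. None of these steps offers a size to carry forward. All three compounds sit at the limit of > 100000 nM in this assay, at which 3 of the 3 values shown sit, with cyclohexyl, phenyl or 4-methylphenyl on the nitrogen. No step beyond the usual scatter is therefore expected in this assay and no direction can be named. The expected step is a number no higher from compound 3 to compound 4 (the limit leaves the size open) and it rests on that shared limit alone. For compound 4 the estimate is 100000 nM with an expected range from 20000 nM to 200000 nM and the assay may well report only a limit again.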

Compound 4, concentration for 50% growth inhibition: > 100000 nM
Compound 4 ended at the assay's limit (the forecaster's own chance of this, stated with the estimate: 75%); the middle value sits exactly at the limit.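

No size can be read from the steps joining compound 4 to compound 1, compound 2 and compound 3, because both ends of each step are limits, not numbers: the limit of > 100000 nM in this assay, at which 4 of the 4 values shown sit.

These compounds leave open whether cyclohexyl, phenyl, 4-methylphenyl and benzyl on that nitrogen differ at all in growth inhibition.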